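The source may report more compounds than this note shows. Statements on the series, on what has been measured and on what is new or still open speak of the compounds shown alone.

Of the compounds shown here, three built on one shared core have been measured in a functional assay on SF-268 cells (Homo sapiens) for inhibition, read by sulforhodamine B assay, with a stated time of 48 h, tested at 10 uM; a higher number here means more inhibition at the concentration tested (going by the name of the read-out), a lower number less inhibition. Compound 1 `Brc1cn2ccnc2c(-c2ccc3ncn(C4CCCCC4)c3c2)n1` gives 17.1%. Compound 2 `c1ccc2c(-c3cn4ccnc4c(-c4ccc5ncn(C6CCCCC6)c5c4)n3)cccc2c1` gives 7.84%. Compound 3 `Clc1ccc(-c2cn3ccnc3c(-c3ccc4ncn(C5CCCCC5)c4c3)n2)cc1` gives 4.83%. Compound 3 sits at the low end of this small set: its gap to compound 2 lies within the scatter, whereas compound 1 stands beyond it, as the step of a number 12.3 percentage points lower from compound 1 to compound 3 (beyond the scatter) shows. The step of a number 9.3 percentage points lower from compound 1 to compound 2 (within the scatter) stays within the scatter, and so does a number 3 percentage points lower from compound 2 to compound 3 (within the scatter).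

Compound 4 `FC(F)(F)c1cccc(-c2cn3ccnc3c(-c3ccc4ncn(C5CCCCC5)c4c3)n2)c1` differs from compound 3 in one place: 3-(trifluoromethyl)phenyl in place of 4-chlorophenyl on an aromatic carbon. One aromatic ring of carbon only gives way to another, so the measured step that bears most directly on it is the earlier swap of one such ring for another, a number 3 percentage points lower from compound 2 to compound 3 (within the scatter), which stayed within the scatter. The larger step of a number 12.3 percentage points lower from compound 1 to compound 3 (beyond the scatter) replaced a bromo group by a whole ring, a different kind of change, and offers less guidance. Among the measured compounds shown here, nothing among the measured compounds suggests that exchanging 4-chlorophenyl for 3-(trifluoromethyl)phenyl would move the number beyond the scatter in either direction. Compound 4 is therefore expected to give 6% in this assay, with a range from 0% to 15%, which means an expected step of a number 1.2 percentage points higher from compound 3 to compound 4 (within the scatter) that lies within the scatter.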

Compound 4, a percentage reported as inhibition, at one concentration (the size of the read-out at that concentration, not a potency): 3.3%
Estimate against measurement, compound 4: 2.7 percentage points above, and the stated range covers the measured number.
By their numbers in this assay, from the lowest: compounds 4, 3, 2 and 1 (each within the scatter of the next, the first and the last beyond it).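

In this assay, the swap of one carbon-only aromatic ring for another again leaves the number within the scatter, as shown by a number 1.5 percentage points lower from compound 3 to compound 4 (within the scatter) and by a number 4.5 percentage points lower from compound 2 to compound 4 (within the scatter) in the listed comparisons. So naphthalen-1-yl, 4-chlorophenyl and 3-(trifluoromethyl)phenyl cannot be told apart here, even though the new group has more heavy atoms, carries fluorine rather than chlorine, and has its substituent at a different ring position, as the names show. Among the compounds shown here, the step of a number 13.8 percentage points lower from compound 1 to compound 4 (beyond the scatter) joins the one to compound 3 in lying beyond the scatter, which points to a gap between the bromo compound and these ring compounds, but compound 2 goes against this pattern, since its step from compound 1 stays within the scatter.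

As far as these compounds go, what a group of another kind at this position would do remains open, for example an amine, a carboxylic acid or a short alkyl chain. Nothing available here explains the difference between bromo and the two phenyl groups.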